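Swapping trifluoromethyl for methoxy in a cytotoxicity series

This account rests on a few compounds, and the source may have more. Where it says the series, first, only, none or still open, it means among the compounds named here.

Of the compounds shown here, three sharing one core have been tested in a functional assay on HCT-15 cells (Homo sapiens) for cytotoxicity, read by MTT assay, with a stated time of 2 days; a lower number here means a stronger inhibitor, a higher number a weaker inhibitor. Compound 1 `Cc1cccc(-c2nc3ccc(C)cc3c(=O)[nH]2)c1` gives > 50000 nM, which is a limit of the assay and not a number. Compound 3 `Cc1ccc2nc(-c3cccc(C(F)(F)F)c3)[nH]c(=O)c2c1` gives > 50000 nM, which is also a limit. Compound 2 `Cc1ccc2nc(-c3ccccc3C)[nH]c(=O)c2c1` gives an actual number, 11700 nM. Compound 3 therefore has no number of its own and stands at the limit of > 50000 nM in this assay, at which 2 of the 3 values shown sit.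

The next compound is compound 4 `COc1cccc(-c2nc3ccc(C)cc3c(=O)[nH]2)c1`, with methoxy in place of trifluoromethyl on an aromatic carbon, meta to a large group: methoxy in place of trifluoromethyl on an aromatic carbon. Among the measured compounds shown here, the only measured step at this place is a step that the two limits leave unreadable from compound 1 to compound 3, so it offers no size to carry over. Both groups tested at this place, in compound 1 and compound 3, left the result at the limit. Only compound 2, whose methyl sits elsewhere, reaches a number, at 11700 nM, and it goes against that picture.

Compound 4 is therefore expected to stay close to the limit, and the assay may well report only a limit again. The expected change is an at least 1.2-fold lower number from compound 3 to compound 4 (0.09 log units; that floor lies within the scatter), with no step beyond the scatter anticipated in this assay. For compound 4 the estimate is 40000 nM, with an expected range from 14000 nM to 80000 nM.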

Compound 4, half-maximal inhibitory concentration: 32000 nM
Compound 4: the middle estimate sits 1.3-fold (0.10 log units) above what was measured; measured number inside the range.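

In this assay, among the compounds shown here, compound 4 is the first compound with a group at this place, on an aromatic carbon meta to a large group, to give an actual number instead of a limit. Methoxy in place of trifluoromethyl gives an at least 1.5-fold lower number from compound 3 to compound 4 (0.19 log units; that floor lies within the scatter), and methoxy in place of methyl gives an at least 1.5-fold lower number from compound 1 to compound 4 (0.19 log units; that floor lies within the scatter); each step is only a floor, so the true difference could be larger, but on the printed figures alone neither floor clears the usual scatter. Both steps start from a limit and not from a number, which is why their full size cannot be read: the limit of > 50000 nM in this assay, at which 2 of the 4 values shown sit.

On these data alone, whether an amine, a hydroxyl or a longer chain such as ethoxy at this same place would give a lower number than compound 4 remains open. Also open, as far as these compounds go, is how methoxy would fare at the place held by the methyl of compound 2, which differs from compound 4 in more than one place and so cannot be compared with it directly.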